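Amine chain length in dodecylamide series: interpolating compound 3

The source may hold more compounds than are shown below. What is called first, only, known or untested is meant among the compounds shown, and "the series" means these compounds.

Compound 1 `CCCCCCCCCCCCNC(=O)C(N)CN` and compound 2 `CCCCCCCCCCCCNC(=O)C(N)CCCN` share the dodecylamide core and differ only in the length of the amine-bearing side chain. In a functional assay on HL-60 cells (Homo sapiens) for activation (on this read-out lower numbers stand for an effect already at smaller amounts and higher numbers for an effect only at larger amounts of compound), compound 1 gives 2510 nM, and in this assay compound 2 gives 2510 nM. Going by the values given here, the one measured step, no change at the digits printed from compound 1 to compound 2 (within the scatter), therefore shows that lengthening the side chain by one unit left the read-out unchanged within the scatter. Compound 2 stands level with compound 1 at the digits shown; the two cannot be placed in order.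

Compound 3 `CCCCCCCCCCCCNC(=O)C(N)CCN` is the next member to be measured. It differs from compound 2 by amino in place of aminomethyl on a saturated chain carbon, three bonds along the chain from an amine nitrogen and a carbonyl carbon. This change places compound 3 between compound 1 and compound 2 in side-chain length. Among the compounds with values here, the only step that bears on it is the one from compound 1 to compound 2, which was flat, so the step to compound 3 is expected to be no change at the digits printed from compound 2 to compound 3 (within the scatter) in this assay, with no direction beyond the scatter. Compound 3 is accordingly estimated at 2510 nM in this assay, in the range 1100 nM to 5700 nM.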

Compound 3, half-maximal effective concentration: 1260 nM
The estimate for compound 3 lay 2.0-fold (0.30 log units) above the measured number; the measured number falls inside the stated range.
By their numbers in this assay, from the lowest: compounds 3, 1 and 2 (each within the scatter of the next).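

Amino in place of aminomethyl on a saturated chain carbon, three bonds along the chain from an amine nitrogen and a carbonyl carbon, gives in this assay a 2.0-fold lower number from compound 2 to compound 3 (0.30 log units; within the scatter) and so does not leave the scatter. Aminomethyl in place of amino on a saturated chain carbon, two bonds along the chain from an amine nitrogen and a carbonyl carbon, gives a 2.0-fold lower number from compound 1 to compound 3 (0.30 log units; within the scatter) and reads the same way. With compound 3 added, compounds 1, 2 and 3 all lie within the scatter of one another, so the flat reading of the first pair now holds across all three side chains, no side chain can be ranked over another on this read-out, and no information is available that would account for the numbers.

From the compounds shown here alone, whether a 4-aminobutyl or longer side chain would move the read-out beyond the scatter remains open, as does the outcome of replacing the terminal amine with a carboxylic acid or a hydroxyl group. Also open, going by these compounds, is how far the read-out depends on the dodecyl chain, which a decyl or tetradecyl chain on the same core would test.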